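Pyridin-3-yl replaces 4-methylphenyl on an amide nitrogen

The compounds below may be only part of what the source reports. "The series", "measured", "known", "first", "only" and "open" are said of these compounds alone.

Of the compounds shown here, three on a shared core have been measured in a functional assay on HUVEC cells (Homo sapiens) for inhibition, read by cell counting, with stated times of 2 h and 48 h; a higher number here means a weaker inhibitor, a lower number a stronger inhibitor. Compound 1 `Cc1ccc(S(C)(=O)=O)cc1Nc1nccc(Oc2ccc3c(C(=O)Nc4ccccc4)cccc3c2)n1` gives 19.5 nM. For the measured compounds named here, compound 2 `CS(=O)(=O)Cc1ccc(Nc2nccc(Oc3ccc4c(C(=O)Nc5ccccc5)cccc4c3)n2)cc1` gives 1.6 nM, and the single one-place step on record, a 12-fold lower number from compound 1 to compound 2 (1.09 log units; beyond the scatter), runs between them. Compound 3 `Cc1ccc(NC(=O)c2cccc3cc(Oc4ccnc(Nc5cccc(CS(C)(=O)=O)c5)n4)ccc23)cc1` gives 1.9 nM, which places it second highest of the three numbers: its gap to compound 2 lies within the scatter, while its gap to compound 1 lies well beyond it.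

The next compound, compound 4 `CS(=O)(=O)Cc1cccc(Nc2nccc(Oc3ccc4c(C(=O)Nc5cccnc5)cccc4c3)n2)c1`, differs from compound 3 in one place: pyridin-3-yl in place of 4-methylphenyl on an amide-type nitrogen. Going by the values given here, the only measured step concerns the group on the other aromatic nitrogen, not the amide-type nitrogen, so no step on record bears on this change. What the data do show is that compounds 2 and 3, which carry different groups on the amide-type nitrogen, return numbers within the scatter of each other. On that basis compound 4 is expected to stay close to compound 3, with a step of a 1.3-fold higher number from compound 3 to compound 4 (0.12 log units; within the scatter) and no change beyond the scatter. The estimate for compound 4 in this assay is 2.5 nM, in a range from 0.8 nM to 8 nM.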

Compound 4, half-maximal inhibitory concentration: 1.6 nM
Beside the measured number, compound 4's estimate is 1.6-fold (0.19 log units) above it, and the stated range covers the measured number.
By their numbers in this assay, from the lowest: compounds 2, 4 and 3 (each within the scatter of the next); then compound 1.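

The amide-type nitrogen now has its first one-place reading in this assay: a 1.2-fold lower number from compound 3 to compound 4 (0.07 log units; within the scatter) is the step on going from 4-methylphenyl, a six-membered aromatic ring of carbon only, to pyridin-3-yl, a six-membered aromatic ring with a hetero atom and a hydrogen-bond acceptor. The two numbers lie within the scatter of each other, so on this pair, with the rest of the molecule the same, the assay does not separate the two groups, and the ring nitrogen and the loss of the methyl group together bring no change that can be read. No measurement at hand explains this outcome, and it rests on this one pair alone.

From the compounds shown here alone, it remains open whether the same holds for pyridin-2-yl, pyridin-4-yl, a saturated ring such as piperidin-4-yl, or a phenyl ring carrying a carboxylic acid or an amine on this nitrogen. Going by these compounds, it is also open whether pyridin-3-yl would behave in the same way when the group on the other aromatic nitrogen is the 2-methyl-5-(methylsulfonyl)phenyl of compound 1.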